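Swapping a methoxy for a chloro on a weakly active amine

A few compounds are considered here, and "the series" means these few. Any claim that something is new, unique, unknown or untested is made for them only; others in the source may bear on it.

Compound 1 `COc1ccc(-c2nn3cc(-c4cccc(N)c4)nc3s2)cc1OC` gives 26000 nM in a functional assay on HeLa cells (Homo sapiens) for inhibition, read by cell counting, with a stated time of 4 days; on this read-out higher numbers stand for weaker inhibition and lower numbers for stronger inhibition. Compound 2 `COc1ccc(-c2nn3cc(-c4cccc(N)c4)nc3s2)cc1` reaches only the limit of the assay, >= 250000 nM, so no number is known for it. Compound 3 `C=C(Br)C(=O)Nc1cccc(-c2cn3nc(-c4ccc(OC)cc4)sc3n2)c1` gives 2300 nM. Removing a methoxy gave an at least 9.6-fold higher number from compound 1 to compound 2 (0.98 log units; beyond the scatter), while adding the acyl group gave an at least 100-fold lower number from compound 2 to compound 3 (2.03 log units; beyond the scatter). Compound 4 `Nc1cccc(-c2cn3nc(-c4ccc(Cl)cc4)sc3n2)c1` differs from compound 2 by chloro in place of methoxy on an aromatic carbon. Within the data shown here, neither measured step involves a chloro, and the only methoxy change sits elsewhere, so no clear direction is expected. Compound 2 stands at a limit, so compound 4 is estimated near that limit, at 150000 nM, with a wide range from 20000 nM to 400000 nM; the expected step is an at least 1.6-fold lower number from compound 2 to compound 4 (0.22 log units; that floor lies within the scatter).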

Compound 4, half-maximal inhibitory concentration: 160000 nM
Compound 4: the middle estimate sits 1.1-fold (0.03 log units) below what was measured; low and high end bracket the measured number.
By their numbers in this assay, from the lowest: compound 3; then compound 1; then compound 4. At a limit, above all of these: compound 2.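

Chloro in place of methoxy, para to a large group, brings an at least 1.5-fold lower number from compound 2 to compound 4 (0.19 log units; that floor lies within the scatter). Among these compounds, this is the first change at this position with a measured number on one side, but that floor does not separate chloro from methoxy. Compound 2 stands at a limit of the assay, so the true size of the step stays unknown: the limit of >= 250000 nM in this assay, at which 1 of the 4 values shown sits.

The compounds shown leave open how a fluoro, a methyl or a hydroxyl would compare at this position. They also leave open whether chloro in place of methoxy would shift the number of compound 3, which carries the (1-bromoethenyl)carbonyl group on its nitrogen.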